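This account rests on a few compounds, and the source may have more. Where it says the series, first, only, none or still open, it means among the compounds named here.

Working notes on the cytotoxicity series.

The set shares one macrocyclic core and differs in the pendant aryl group and in the substitution of the fused bicyclic ring. Compound 1 `COc1cc2c(O[C@H]3C[C@H]4C(=O)N(C)CCCC/C=C/[C@@H]5C[C@@]5(C(=O)NS(=O)(=O)C5(C)CC5)NC(=O)N4C3)cc(-c3nc(C(C)C)cs3)nc2cc1Cl` carries an isopropyl-thiazole. In an ADME assay on Huh-7 cells (Homo sapiens) for cytotoxicity, read by colorimetric assay (a lower number here means that less compound is tolerated, a higher number that more compound is tolerated), compound 1 reaches only the assay limit, reported as > 75000 nM; this is a limit, not a number (the limit of > 75000 nM in this assay, at which 1 of the 3 values shown sits). Compound 2 `COc1ccc2c(O[C@H]3C[C@H]4C(=O)N(C)CCCC/C=C/[C@@H]5C[C@@]5(C(=O)NS(=O)(=O)C5(C)CC5)NC(=O)N4C3)cc(-c3csc(C(C)C)n3)nc2c1Cl` gives 30200 nM in this assay. Compound 3 `COc1ccc2c(O[C@H]3C[C@H]4C(=O)N(C)CCCC/C=C/[C@@H]5C[C@@]5(C(=O)NS(=O)(=O)C5CC5)NC(=O)N4C3)cc(-c3csc(C(F)(F)F)n3)nc2c1C` gives 75000 nM in this assay. Among the two numbers shown, compound 2 stands lowest; the gap to compound 3 lies beyond the usual scatter.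

Compound 4 `COc1ccc2c(O[C@H]3C[C@H]4C(=O)N(C)CCCC/C=C/[C@@H]5C[C@@]5(C(=O)NS(=O)(=O)C5(C)CC5)NC(=O)N4C3)cc(-n3cc(C(C)C)nn3)nc2c1Cl` has not yet been measured in this assay. Its difference from compound 2 is 4-isopropyl-1H-1,2,3-triazol-1-yl in place of 2-isopropyl-1,3-thiazol-4-yl on an aromatic carbon. Within the data shown here, no measured pair isolates this change, so the size of the step in this assay is open. The expectation is a modest shift toward a higher tolerated concentration, a 1.5-fold higher number from compound 2 to compound 4 (0.17 log units; within the scatter), though a step within the scatter would not be surprising. Compound 4 is therefore estimated at 45000 nM, with a range from 20000 nM to 90000 nM.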

Compound 4, half-maximal cytotoxic concentration: 28500 nM
Estimate against measurement, compound 4: 1.6-fold (0.20 log units) above, within the range that was stated.
By their numbers in this assay, from the lowest: compounds 4 and 2 (each within the scatter of the next); then compound 3.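

In this assay, among these compounds, the exchange of 2-isopropyl-1,3-thiazol-4-yl for 4-isopropyl-1H-1,2,3-triazol-1-yl on this aromatic carbon, next to the ring nitrogen, gives the first step that isolates one place: a 1.1-fold lower number from compound 2 to compound 4 (0.03 log units; within the scatter). At this position, then, a five-membered aromatic ring with 2 hetero atoms gives way to one with 3 hetero atoms with no step beyond the scatter, a reading that holds for this pair alone. The one limit in the set belongs to compound 1, and it is a limit, not a number: the limit of > 75000 nM in this assay, at which 1 of the 4 values shown sits.

As far as these compounds go, whether this tolerance extends to a triazole bearing an amine or a carboxylic acid in place of the isopropyl remains open. Compound 3 differs from compound 2 in more than one place, so its higher number cannot be assigned to any single group.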